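Aminothiazole ketones: effect of removing one methoxy group

A few compounds are considered here, and "the series" means these few. Any claim that something is new, unique, unknown or untested is made for them only; others in the source may bear on it.

Among the measured compounds shown here, compound 1 `COc1ccc(C(=O)c2sc(Nc3ccccc3)nc2N)cc1OC` is the only member of the set with a number in a functional assay on MOLT-4 cells (Homo sapiens) for antiproliferative activity, read by cell counting, with a stated time of 2 days; a lower number here means a stronger inhibitor, a higher number a weaker inhibitor: compound 1 gives 5500 nM. Compound 2 `COc1ccc(C(=O)c2sc(Nc3ccc(Cl)cc3)nc2N)cc1` gives > 10000 nM in this assay, a limit rather than a number. Compound 3 `Nc1nc(Nc2ccc(Cl)cc2)sc1C(=O)c1ccccc1` likewise gives > 10000 nM, again a limit. The difference between the cores of compound 1 and compound 2 is not broken down here.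

Compound 2 and compound 3 differ by hydrogen in place of methoxy on an aromatic carbon. The step that the two limits leave unreadable from compound 2 to compound 3 cannot be sized, because of the limit of > 10000 nM in this assay, at which 2 of the 3 values shown sit.

Compound 4 `COc1cccc(C(=O)c2sc(Nc3ccccc3)nc2N)c1` is not yet measured. It differs from compound 1 by hydrogen in place of methoxy on an aromatic carbon. This is the same kind of change as that from compound 2 to compound 3, but the surroundings are not the same: in compound 1 the carbon that loses its methoxy is ortho to a methoxy group (2 heavy atoms) and para to a large group, whereas in compound 2 it is para to a large group only.

The measured data give no size for this change, and both single-methoxy and no-methoxy partners of the chloro series sit at the limit. For the measured compounds named here, the only number available is that of compound 1, 5500 nM. The step from compound 1 to compound 4 is expected to be a 2.0-fold higher number from compound 1 to compound 4 (0.30 log units; within the scatter), a loss, on the grounds that compound 2, which carries a single methoxy, reaches only > 10000 nM. Compound 4 is therefore estimated at 11000 nM, within 3500 nM to 35000 nM, with a fair chance that this assay returns only a limit.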

Compound 4, half-maximal inhibitory concentration: 1300 nM
The estimate for compound 4 lay 8.5-fold (0.93 log units) above the measured number; the whole stated range lies above it.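

Hydrogen in place of methoxy on an aromatic carbon gives a 4.2-fold lower number from compound 1 to compound 4 (0.63 log units; beyond the scatter) in this assay, so on the core of compound 1 this single change brings a modest gain, beyond the usual scatter. The same change on the core of compound 2 cannot be read, because compound 2 and compound 3 both stop at a limit and neither has a number: the limit of > 10000 nM in this assay, at which 2 of the 4 values shown sit. The gain therefore rests on one pair only; it is neither confirmed nor contradicted on the second core, and the two cases also differ in place, since the carbon that loses its methoxy in compound 1 is ortho to a methoxy group, whereas in compound 2 it is para to a large group only.

The compounds shown leave open what happens on the core of compound 1 when the remaining methoxy of compound 4 also gives way to hydrogen, and whether a methoxy at that carbon is simply dispensable or can be improved on. Other groups at the carbon that lost its methoxy in compound 4, such as an amine, a carboxylic acid or a longer ether chain like ethoxy, remain outside this set.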